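This account rests on a few compounds, and the source may have more. Where it says the series, first, only, none or still open, it means among the compounds named here.

Compounds 1, 2 and 3 were all tested in a functional assay on L1210 cells (Mus musculus), with a stated time of 48 h; a higher number here means a weaker inhibitor, a lower number a stronger inhibitor. Compound 1, `CCOC(=O)Nc1cc(NC(C)C(O)COc2ccccc2)c([N+](=O)[O-])c(N)n1`, gives 55000 nM. Compound 3, `CCOC(=O)Nc1cc(NC(C)C(O)COc2ccccc2)c(N)c(N)n1`, gives 21000 nM. These two differ in one place only, (amino in place of nitro on an aromatic carbon), and that change made the step of a 2.6-fold lower number from compound 1 to compound 3 (0.42 log units; beyond the scatter). Compound 2, `CCCCC(Nc1cc(NC(=O)OCC)nc(N)c1[N+](=O)[O-])C(C)O`, gives 56000 nM; its result and that of compound 1 lie within the usual scatter of each other, while its gap to compound 3 lies beyond it. How the core of compound 2 differs from the core of compound 1 is not broken down here.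

Compound 4, `CCCCC(Nc1cc(NC(=O)OCC)nc(N)c1N)C(C)O`, has not yet been measured in this assay. It stands to compound 2 as compound 3 stands to compound 1: the change is amino in place of nitro on an aromatic carbon. This is the same kind of change as the earlier one, not exactly the same, since the surroundings are described alike except that the neighbouring group is counted as 9 heavy atoms in one case and simply called large in the other. Within the data shown here, only this one earlier instance is available, so the expectation rests on a single point. That earlier change made the step of a 2.6-fold lower number from compound 1 to compound 3 (0.42 log units; beyond the scatter), and compound 2 gives 56000 nM. On that basis the step expected is a 2.7-fold lower number from compound 2 to compound 4 (0.43 log units; beyond the scatter), roughly the size of the earlier one. Compound 4 is accordingly estimated at 21000 nM, with a likely range from 9000 nM to 50000 nM.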

Compound 4, half-maximal inhibitory concentration: 1700 nM
For compound 4 the middle estimate is 12-fold (1.09 log units) above the measured one, outside the stated range (below it).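

In this assay, amino in place of nitro on an aromatic carbon gave a 33-fold lower number from compound 2 to compound 4 (1.52 log units; beyond the scatter), so the number fell on this core just as it did on the core of compound 1. The direction of the change therefore carried over between the two cores, but its size did not: the same change on two cores in this assay, a 2.6-fold lower number (0.42 log units; beyond the scatter) from compound 1 to compound 3 and a 33-fold lower number (1.52 log units; beyond the scatter) from compound 2 to compound 4, 13-fold (1.10 log units) apart, beyond the scatter of two such steps This shows that the step measured on one core was a poor guide to the size of the step on the other, yet two pairs cannot show which part of the cores sets the size, or what size a third core would give.

Still open, on these data alone, is whether the amino group itself matters or whether simply losing the nitro group is enough, which a methylamino group, an acetylamino group or a plain hydrogen at the same place on the core of compound 4 could help to separate. Also open, as far as these compounds go, is how far the large step depends on the chain that carries the hydroxyl group, a question that a shorter chain, a longer chain or one ending in a carboxylic acid on that same core could begin to answer.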